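A Second Chloro Group on a Low-Toxicity Quinazoline Series

A few compounds are considered here, and "the series" means these few. Any claim that something is new, unique, unknown or untested is made for them only; others in the source may bear on it.

Three compounds sharing one core were tested in an ADME assay on MT4 cells (Homo sapiens) for cytotoxicity, read by MTT assay, with a stated time of 4 days; on this read-out higher numbers stand for lower toxicity in this test and lower numbers for higher toxicity in this test. Compound 1 `N#Cc1ccc(Nc2nc(Oc3ccccc3Cl)c3ccccc3n2)cc1` gives 38000 nM in this assay. Compound 2 `N#Cc1ccc(Nc2nc(Oc3ccc(Cl)cc3Cl)c3ccccc3n2)cc1` gives 32000 nM in this assay. Compound 3 `COc1cc(C#N)ccc1Oc1nc(Nc2ccc(C#N)cc2)nc2ccccc12` is reported in this assay only as a limit of the test, >= 140000 nM, not as a number.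

Compound 1 and compound 2 differ by chloro in place of hydrogen on an aromatic carbon. That change made a 1.2-fold lower number from compound 1 to compound 2 (0.07 log units; within the scatter). The cores of compound 1 and compound 3 differ by 4-cyano-2-methoxyphenyl in place of 2-chlorophenyl on an oxygen on an aromatic ring, which gave an at least 3.6-fold higher number from compound 1 to compound 3 (0.56 log units; beyond the scatter); the matching difference gave an at least 4.3-fold higher number from compound 2 to compound 3 (0.64 log units; beyond the scatter). Both of these steps rest on (the limit of >= 140000 nM in this assay, at which 1 of the 3 values shown sits), so the true gap is known only as a lower bound.

Compound 4 `COc1cc(C#N)cc(Cl)c1Oc1nc(Nc2ccc(C#N)cc2)nc2ccccc12` has not yet been measured. It differs from compound 3 by chloro in place of hydrogen on an aromatic carbon. This is the same kind of change as that from compound 1 to compound 2, though the surroundings are not the same: in compound 2 the entering chloro sits meta to a chloro group and para to a large group, whereas in compound 4 it sits ortho to a large group, meta to a cyano group and meta to a methoxy group. Since the earlier chloro step a 1.2-fold lower number from compound 1 to compound 2 (0.07 log units; within the scatter) stayed within the scatter, the expected step here is a number no higher from compound 3 to compound 4 (the limit leaves the size open). Compound 4 is therefore estimated at 140000 nM in this assay, with a likely range from 60000 nM to 300000 nM, and the test is quite likely to report only a limit again.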

Compound 4, half-maximal cytotoxic concentration: 220000 nM
Compound 4: middle estimate off by 1.6-fold (0.20 log units), on the low side; the measured number falls inside the stated range.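

No new step can be read from compound 3 to compound 4 in this assay, because compound 3 is reported only as a limit and not as a number: the limit of >= 140000 nM in this assay, at which 1 of the 4 values shown sits.

The compounds shown leave open where the true value of compound 3 lies, and so whether chloro in place of hydrogen on an aromatic carbon changes the number in this pair at all.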